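The source may report more compounds than this note shows. Statements on the series, on what has been measured and on what is new or still open speak of the compounds shown alone.

Working notes on the series. Three compounds share one core and are read in a functional assay on ASPC1 cells (Homo sapiens) for inhibition, read by MTT assay, with a stated time of 72 h; a lower number here means a stronger inhibitor of growth, a higher number a weaker inhibitor of growth. Compound 1 `O=S(=O)(NCCCNCc1ccc(Cl)c(Cl)c1)c1cc(C(F)(F)F)cc(C(F)(F)F)c1` gives 2800 nM. Compound 2 `O=S(=O)(NCCCNCc1cccc2ccccc12)c1cc(C(F)(F)F)cc(C(F)(F)F)c1` gives 21000 nM. Compound 3 `COc1cccc(CNCCCNS(=O)(=O)c2cc(C(F)(F)F)cc(C(F)(F)F)c2)c1` gives 3800 nM, the second highest of the three numbers; its nearest neighbour is compound 1, and the gap a 1.4-fold higher number from compound 1 to compound 3 (0.13 log units; within the scatter) lies within the scatter, while the gap to compound 2 is wider, as a 5.5-fold lower number from compound 2 to compound 3 (0.74 log units; beyond the scatter) shows. The other measured step, a 7.5-fold higher number from compound 1 to compound 2 (0.88 log units; beyond the scatter), points the same way: only the naphthalen-1-yl compound stands clearly apart.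

Compound 4 `O=S(=O)(NCCCNCc1ccc(Cl)cc1)c1cc(C(F)(F)F)cc(C(F)(F)F)c1` is not yet measured. The change from compound 3 is 4-chlorophenyl in place of 3-methoxyphenyl on a saturated chain carbon bound to an amine nitrogen. Among the measured compounds shown here, compound 4 thus carries a single chlorine on the ring where compound 1 carries two, and the step that bears on it most is a 1.4-fold higher number from compound 1 to compound 3 (0.13 log units; within the scatter), which is within the scatter; the 4-chlorophenyl compound sits structurally between compound 1 and compound 3 and nothing among the measured steps suggests it should leave their range. The expected step of a 1.2-fold lower number from compound 3 to compound 4 (0.06 log units; within the scatter) is therefore estimated to stay within the scatter. Compound 4 is expected to give 3300 nM in this assay, with a range of 1400 nM to 8000 nM.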

Compound 4, concentration for 50% growth inhibition: 3000 nM
Compound 4: the middle estimate sits 1.1-fold (0.04 log units) above what was measured; measured number inside the range.
By their numbers in this assay, from the lowest: compounds 1, 4 and 3 (each within the scatter of the next); then compound 2.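

In this assay, among the compounds shown here, the step (a 1.1-fold higher number from compound 1 to compound 4 (0.03 log units; within the scatter)), hydrogen in place of chloro on an aromatic carbon, is the first change confined to one substituent on the ring, and it stays within the scatter, so 4-chlorophenyl and 3,4-dichlorophenyl cannot be told apart here. The step (a 1.3-fold lower number from compound 3 to compound 4 (0.10 log units; within the scatter)) also stays within the scatter, so compounds 1, 3 and 4 form one group despite their different ring substituents, while the step (a 7.0-fold lower number from compound 2 to compound 4 (0.85 log units; beyond the scatter)) lies beyond it and confirms with a further comparison that, among these four compounds, only the naphthalen-1-yl group in compound 2 stands apart, with no compound going against this. Nothing available bears on why the three substituted phenyl groups read alike or why compound 2 differs.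

Going by these compounds, it remains open whether a naphthalen-2-yl group would read like compound 2 or like the substituted phenyl compounds. The compounds shown also leave open how a pyridine ring in place of the phenyl ring, or a longer chain in the linker of the shared core, would read in this assay.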